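Cyclohexyl for oxolan-2-yl on the piperazine side chain

The compounds below may be only part of what the source reports. "The series", "measured", "known", "first", "only" and "open" are said of these compounds alone.

The measured compounds:
compound 1, `Cc1cccc2sc(NC(=O)CCN3CCN(CCN(C)C)CC3)nc12`, > 1000 nM
compound 2, `CCCCCCN1CCN(CCC(=O)Nc2nc3c(C)cccc3s2)CC1`, 158 nM
compound 3, `Cc1cccc2sc(NC(=O)CCN3CCN(CC4CCCO4)CC3)nc12`, 5000 nM

Three compounds share a core and differ only in the group on the distal nitrogen of the ring. In an assay on membranes from liver for displacement of a labelled ligand from Sigma intracellular receptor 2 (Rattus norvegicus), read by scintillation counting, with a stated time of 120 min (a lower number here means a stronger inhibitor, a higher number a weaker inhibitor), compound 2 gives 158 nM. Compound 3 gives 5000 nM, the highest of the two numbers measured. For compound 1 the assay reports only a limit, > 1000 nM, so no number is known for it. Among the measured compounds shown here, the one readable step between measured compounds is a 32-fold higher number from compound 2 to compound 3 (1.50 log units; beyond the scatter); the step that the limit leaves unreadable from compound 1 to compound 3 cannot be sized because of the limit of > 1000 nM in this assay, at which 1 of the 3 values shown sits.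

Compound 4, `Cc1cccc2sc(NC(=O)CCN3CCN(CC4CCCCC4)CC3)nc12`, has not yet been measured. It differs from compound 3 by cyclohexyl in place of oxolan-2-yl on a saturated chain carbon bound to an amine nitrogen in a ring. For the measured compounds named here, the only step that bears on this change is the one from compound 2 to compound 3, where a ring with an oxygen replaced a chain of carbon and the number rose sharply. Returning to a ring of carbon only is therefore expected to move the number back in the direction of compound 2, though compound 4 carries a ring rather than a chain, so the size of the return is uncertain. The expected step is a 17-fold lower number from compound 3 to compound 4 (1.22 log units; beyond the scatter). Compound 4 is estimated at 300 nM, with a range of 80 nM to 1200 nM.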

Compound 4, inhibition constant: 519 nM
For compound 4 the middle estimate is 1.7-fold (0.24 log units) below the measured one, and the stated range covers the measured number.
By their numbers in this assay, from the lowest: compound 2; then compound 4; then compound 3.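

In this assay, among the compounds shown here, cyclohexyl in place of oxolan-2-yl gives a 9.6-fold lower number from compound 3 to compound 4 (0.98 log units; beyond the scatter), which shows that a ring on this saturated chain carbon bound to an amine nitrogen in a ring is compatible with a much lower number than compound 3 reached; the earlier compounds had compared a chain only with the oxygen-containing ring. The ring of carbon only does not fully match the open chain, as cyclohexyl in place of pentyl gives a 3.3-fold higher number from compound 2 to compound 4 (0.52 log units; beyond the scatter), and compound 2 keeps the lowest number of the series. Compound 1 is known only through a limit, > 1000 nM, and the step to the new compound, an at least 1.9-fold lower number from compound 1 to compound 4 (0.28 log units; that floor lies within the scatter), gives only a floor and no true size: the limit of > 1000 nM in this assay, at which 1 of the 4 values shown sits.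

The change from oxolan-2-yl to cyclohexyl alters the ring size and removes the oxygen at once, leaving open which of the two accounts for the step, a question that cyclopentyl or oxan-4-yl on the same chain carbon would address. On these data alone, it also remains open how phenyl, a piperidine ring or a longer carbon chain would read at this position.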